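The compounds below may be only part of what the source reports. "The series", "measured", "known", "first", "only" and "open" are said of these compounds alone.

Series built on the shared core of compound 1 `COc1ccc(N2CCN(Cc3csc(N)c3C(=O)c3ccc(Cl)cc3)CC2)cc1` and compound 2 `Nc1scc(CN2CCN(c3cc(F)ccc3F)CC2)c1C(=O)c1ccc(Cl)cc1`, varied only at the amine nitrogen in a ring. In a functional assay on CHO cells with adenosine receptor A1 (Homo sapiens) as the target, read by cAMP accumulation and immunoassay, with a stated time of 6 min, tested at 1 uM (on this read-out higher numbers stand for a weaker effect at the one concentration tested and lower numbers for a stronger effect), compound 1 gives -15%, the highest of the two numbers shown; compound 2 gives -59%. Going by the values given here, the single measured step, a number 44 percentage points lower from compound 1 to compound 2 (beyond the scatter), goes with 2,5-difluorophenyl in place of 4-methoxyphenyl on an amine nitrogen in a ring. Compound 3 `Nc1scc(CN2CCN(c3ccccc3Cl)CC2)c1C(=O)c1ccc(Cl)cc1` carries 2-chlorophenyl in place of 4-methoxyphenyl on an amine nitrogen in a ring. Among the compounds with values here, only the step from compound 1 to compound 2 bears on this change, since both replace the same 4-methoxyphenyl on the same ring nitrogen, though 2-chlorophenyl is not 2,5-difluorophenyl and the size cannot be read across exactly. A step in the same direction, of comparable size, is therefore expected, a number 30 percentage points lower from compound 1 to compound 3 (beyond the scatter). For compound 3 in this assay the expected value is -45%, within a range of -75% to -15%.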

Compound 3, a percentage reported as activity, at one concentration (the size of the read-out at that concentration, not a potency): -5.2%
Compound 3: middle estimate off by 39.8 percentage points, on the low side, outside the stated range (above it).
By their numbers in this assay, from the lowest: compound 2; then compounds 1 and 3 (each within the scatter of the next).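

In this assay, 2-chlorophenyl in place of 4-methoxyphenyl on the amine nitrogen in a ring gives a number 9.8 percentage points higher from compound 1 to compound 3 (within the scatter), so this exchange does not repeat the large step seen with 2,5-difluorophenyl. The direct comparison of the two halogen-bearing groups, a number 53.8 percentage points higher from compound 2 to compound 3 (beyond the scatter), shows that a halogen on the phenyl is not enough for the low number: among these three compounds it belongs to compound 2 alone, and compound 3 goes against any broader reading. Nothing available here gives a reason for the gap between these two groups.

Still open, as far as these compounds go, is whether a phenyl with a single fluorine or an unsubstituted phenyl would stand with compound 2 or with compound 3. With one concentration per compound, these numbers also leave potency open.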